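This account rests on a few compounds, and the source may have more. Where it says the series, first, only, none or still open, it means among the compounds named here.

Measured compounds in an assay on HEK293-A cells for activation of Nicotinamide phosphoribosyltransferase (Homo sapiens), tested at 3 uM; on this read-out higher numbers stand for a stronger effect at the one concentration tested and lower numbers for a weaker effect:
- compound 1, `Cc1ccc(CN2CCc3cc(NC(=O)NCc4ccncc4)ccc32)cc1`: "not determined" (no result reported)
- compound 2, `Cc1ccc(C(=O)n2ccc3cc(NC(=O)NCc4ccncc4)ccc32)cc1`: 76%
- compound 3, `O=C(NCc1cn[nH]c1)Nc1ccc2nc(-c3ccccc3)nn2c1`: 154%

For the measured compounds named here, compound 1 carries no number, so only two values can be set against each other. Compound 3 holds the higher of the two; the gap down to compound 2 lies beyond the scatter of this assay. Going by the values given here, no pair among the measured compounds differs in a single place, so no step size can be read from the measured set itself, and nothing here ties the two numbers to any one structural feature.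

Compound 4, `O=C(NCc1cnco1)Nc1ccc2nc(-c3ccccc3)nn2c1`, has not been measured in this assay. It differs from compound 3 in one place: 1,3-oxazol-5-yl in place of 1H-pyrazol-4-yl on a saturated chain carbon bound to an amide-type nitrogen. The ring that leaves carries the only hydrogen-bond donor of the group; the ring that enters has none and gains an acceptor, with the size and the count of ring hetero atoms otherwise unchanged.

Among the compounds with values here, with no measured step to lean on, a moderate fall in this assay is expected, within or just beyond the scatter, rather than a large one. The expected step is a number 39 percentage points lower from compound 3 to compound 4 (beyond the scatter). Compound 4 is estimated to give 115% in this assay, with a range from 60% to 165%.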

Compound 4, a percentage reported as activity, at one concentration (the size of the read-out at that concentration, not a potency): 123%
For compound 4 the middle estimate is 8 percentage points below the measured one, and the stated range covers the measured number.
By their numbers in this assay, from the lowest: compound 2; then compound 4; then compound 3.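

In this assay, for the compounds shown here, 1,3-oxazol-5-yl in place of 1H-pyrazol-4-yl on a saturated chain carbon bound to an amide-type nitrogen gives a number 31 percentage points lower from compound 3 to compound 4 (beyond the scatter) and provides the first measured single-place step. Compound 4 still gives 123% without a hydrogen-bond donor in this group, so a donor there is not needed for a read-out of this size, although the step cannot separate the loss of the donor from the gain of an acceptor or from the exchange of ring. No measurement on hand accounts for the size of the step.

Going by these compounds, it remains open whether the same exchange gives a similar step on another core. On these data alone, the effect of a 1H-imidazol-4-yl group, a carboxylic acid or a longer chain at this place also remains open.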